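Imidazole to triazole on the oxazolidinone side chain

A few compounds are considered here, and "the series" means these few. Any claim that something is new, unique, unknown or untested is made for them only; others in the source may bear on it.

Three compounds of the series have a number in a physicochemical assay for solubility, read by HPLC, with a stated time of 24 h; on this read-out higher numbers stand for higher solubility and lower numbers for lower solubility. Compound 1 `O=C1CNC(=O)N1C[C@H]1CN(c2ccc(-n3cc(-c4ccccn4)cn3)c(F)c2)C(=O)O1` gives 1630000 nM in this assay. Compound 2 `O=C(OC[C@H]1CN(c2ccc(-n3cc(-c4ccccn4)cn3)c(F)c2)C(=O)O1)c1ccccc1` returns only a limit of this assay, <= 65400 nM, as noted under (the limit of <= 65400 nM in this assay, at which 1 of the 3 values shown sits). Compound 3 `O=C1O[C@@H](Cn2ccnc2)CN1c1ccc(-n2cc(-c3ccccn3)cn2)c(F)c1` gives 12300 nM in this assay, the lowest of the two readable numbers; the step of a 130-fold lower number from compound 1 to compound 3 (2.12 log units; beyond the scatter) and the step of an at least 24-fold lower number from compound 1 to compound 2 (1.39 log units; beyond the scatter) both run downward from compound 1, while the step that the limit leaves unreadable from compound 2 to compound 3 cannot be sized.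

Compound 4 `O=C1O[C@@H](Cn2ccnn2)CN1c1ccc(-n2cc(-c3ccccn3)cn2)c(F)c1` is the next member. Its change from compound 3 is 1H-1,2,3-triazol-1-yl in place of 1H-imidazol-1-yl on a saturated chain carbon bound to a saturated ring carbon. Going by the values given here, none of the measured steps covers an exchange of one five-membered aromatic ring for another; the steps seen replace the dioxoimidazolidinyl group, which is a different kind of change, so they set no direction here. The working expectation for compound 4 is therefore a step of a 1.2-fold lower number from compound 3 to compound 4 (0.09 log units; within the scatter) within the usual scatter, giving an estimated value of 10000 nM in this assay, between 4000 nM and 30000 nM.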

Compound 4, solubility: 247000 nM
The estimate for compound 4 lay 25-fold (1.39 log units) below the measured number; measured number outside the range, above it.
By their numbers in this assay, from the lowest: compound 3; then compound 4; then compound 1.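

In this assay there is a 20-fold higher number from compound 3 to compound 4 (1.30 log units; beyond the scatter), so an exchange of one five-membered aromatic ring for another on a saturated chain carbon bound to a saturated ring carbon is not a neutral swap here, although the two rings have the same count of heavy atoms and neither carries a net charge. The 1H-1,2,3-triazol-1-yl group still falls short of the 2,5-dioxoimidazolidin-1-yl group, with a 6.6-fold lower number from compound 1 to compound 4 (0.82 log units; beyond the scatter), and it stands over the benzoyloxy group, with an at least 3.7-fold higher number from compound 2 to compound 4 (0.57 log units; beyond the scatter). The second of these steps rests on a limit of the assay for compound 2: the limit of <= 65400 nM in this assay, at which 1 of the 4 values shown sits.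

A single pair cannot tell whether the rise follows the number of ring nitrogens or this particular ring. Going by these compounds, a 1H-1,2,4-triazol-1-yl or 1H-tetrazol-1-yl group at the same place would separate the two, and whether the step holds on another core remains open.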